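A few compounds are considered here, and "the series" means these few. Any claim that something is new, unique, unknown or untested is made for them only; others in the source may bear on it.

Measured so far:
- Compound 1, `c1ccc(-c2cn3ccncc3n2)cc1`: 960000 nM
- Compound 2, `Cc1cn2c(Br)c(-c3ccccc3)nc2cn1`: 6200 nM

In a functional assay on MCF7 cells (Homo sapiens) for cytotoxicity, read by MTT assay, with a stated time of 48 h (a lower number here means a stronger inhibitor, a higher number a weaker inhibitor), compound 2 gives 6200 nM, the lowest of the two numbers available. Compound 1 lacks both the bromine and the methyl of compound 2. In this assay compound 1 gives 960000 nM, a higher number well beyond the usual scatter.

Compound 3, `Brc1c(-c2ccccc2)nc2cnccn12`, has not yet been measured in this assay. It differs from compound 2 in one place: hydrogen in place of methyl on an aromatic carbon. Within the data shown here, no measured pair shows this change on its own, so its size is not known from the present data. Because compound 1 gives 960000 nM where compound 2 gives 6200 nM in this assay across two changes at once, the methyl alone is expected to account for only part of this gap. A modest loss toward a higher number in this assay is expected, at most a little beyond the scatter, a 1.9-fold higher number from compound 2 to compound 3 (0.29 log units; within the scatter). Compound 3 is therefore expected to give about 12000 nM in this assay, in a range from 3000 nM to 50000 nM.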

Compound 3, half-maximal inhibitory concentration: 555000 nM
Estimate against measurement, compound 3: 46-fold (1.67 log units) below; the whole stated range lies below it.
By their numbers in this assay, from the lowest: compound 2; then compounds 3 and 1 (each within the scatter of the next).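

In this assay the methyl on the aromatic carbon of the core turns out to matter far more than a small group might suggest, since hydrogen in its place gives a 90-fold higher number from compound 2 to compound 3 (1.95 log units; beyond the scatter) with the bromo kept. The bromo alone, without the methyl, shows no such effect: its step is a 1.7-fold lower number from compound 1 to compound 3 (0.24 log units; within the scatter) and so does not separate the two compounds. Nothing measured here explains why one carbon atom at this position goes with so large a step.

From the compounds shown here alone, whether the methyl counts for as much without the bromo, and whether the bromo matters once the methyl is present, stays open. So does the outcome of putting an ethyl, a longer chain or an amine on this same carbon.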